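Thiazolopiperidine alkynes: an amide in place of isobutyl

A few compounds are considered here, and "the series" means these few. Any claim that something is new, unique, unknown or untested is made for them only; others in the source may bear on it.

Measured compounds, all read in an assay on HEK293 cells for positive allosteric modulation of metabotropic glutamate receptor 5 (Homo sapiens), read by FLIPR, with a stated time of 1 h; a higher number here means that more compound is needed for the effect, a lower number that less compound is needed:
compound 1, `CC(C)CN1CCc2nc(C#Cc3ccccc3)sc2C1` — in this assay compound 1 gives > 10000 nM, a limit of the assay.
compound 2, `Fc1cccc(C#Cc2nc3c(s2)CN(C2CCC2)CC3)c1` — in this assay compound 2 gives > 10000 nM, again a limit.
compound 3, `Fc1cccc(C#Cc2nc3c(s2)CN(C2CCOC2)CC3)c1` — in this assay compound 3 gives > 10000 nM, also a limit.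

Compound 1 therefore stands at the limit, and so do both other measured compounds; the limit of > 10000 nM in this assay, at which 3 of the 3 values shown sit, describes that common position. Within the data shown here, the only one-place step among the measured compounds, a step that the two limits leave unreadable from compound 2 to compound 3, cannot be read in size because both of its ends are limits.

The unmeasured compound 4, `O=C(C1CC12CCC2)N1CCc2nc(C#Cc3ccccc3)sc2C1`, differs from compound 1 in one place: a group of 8 heavy atoms (7 carbon, 1 oxygen; one three-membered non-aromatic ring of carbon only, one four-membered non-aromatic ring of carbon only) in place of a group of 4 heavy atoms (4 carbon; no ring), on an amine nitrogen in a ring. Among the measured compounds shown here, no measured step exchanges an isobutyl on that nitrogen for a carbonyl-bearing group, so nothing among the measured pairs bears directly on this change, and the one step that is available is unreadable. An expectation for compound 4 can thus only rest on where compound 1 stands.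

Compound 4 is estimated at 6000 nM in this assay, with a range of 800 nM to 40000 nM, which would mean a step of an at least 1.6-fold lower number from compound 1 to compound 4 (0.22 log units; that floor lies within the scatter); this estimate is wide and carries a real chance that only a limit is reported again.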

Compound 4, half-maximal effective concentration: 3.9 nM
Compound 4: middle estimate off by 1500-fold (3.19 log units), on the high side; measured number outside the range, below it.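

In this assay, the exchange of isobutyl for the carbonyl-bearing group with its three-membered and four-membered rings, on the amine nitrogen in a ring, gives an at least 2500-fold lower number from compound 1 to compound 4 (3.40 log units; beyond the scatter). Among these compounds, this shows that the position can decide between a limit of the assay and a readable low number, which the earlier compounds could not show, and since one end of the step is a limit, its printed size is only a floor. Compound 4 is the only compound shown that gives a number rather than a limit, and the step from compound 2 to compound 3 cannot be read, so the rest of the series offers no second reading at this position: the limit of > 10000 nM in this assay, at which 3 of the 4 values shown sit.

The compounds shown leave open whether the carbonyl or the ring pair carries the step, a question that a simple acetyl or a cyclopropylcarbonyl group on the same nitrogen would bear on. They also leave open how far the change holds with a different group on the alkyne, such as the fluorophenyl of compound 2 and compound 3 or a pyridine.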